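The source may report more compounds than this note shows. Statements on the series, on what has been measured and on what is new or still open speak of the compounds shown alone.

Measured compounds: compound 1 `O=C(CCCCCc1ccc(F)c(Cl)c1)N1CCOC1=O` gives 26 nM in an assay on HEK293 cells for inhibition of N-acylethanolamine-hydrolyzing acid amidase (Rattus norvegicus), read by LC-MS, with a stated time of 30 min; on this read-out lower numbers stand for stronger inhibition and higher numbers for weaker inhibition; compound 2 `CSc1cccc(CCCCCC(=O)N2CCOC2=O)c1` gives 12800 nM; compound 3 `COc1cccc(CCCCCC(=O)N2CCOC2=O)c1` gives 16300 nM.

Compound 3 stands at the highest of the three numbers in this assay. Its nearest neighbour is compound 2, which lies within the scatter of it; compound 1, with two halogens on the ring, lies far below both. Within the data shown here, the one measured step that touches the same ring position is a 1.3-fold higher number from compound 2 to compound 3 (0.10 log units; within the scatter), a change among small groups on an aromatic carbon that stays within the scatter.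

Compound 4 `NC(=O)c1cccc(CCCCCC(=O)N2CCOC2=O)c1` differs from compound 3 by carbamoyl in place of methoxy on an aromatic carbon. Among the measured compounds shown here, no measured step exchanges a methoxy for a carbamoyl, so the expectation rests only on the single small step from compound 2 to compound 3, which did not move the number beyond the scatter. Compound 4 is therefore expected to give about 20000 nM in this assay, between 5000 nM and 80000 nM, a step of a 1.2-fold higher number from compound 3 to compound 4 (0.09 log units; within the scatter) that is not expected to exceed the scatter.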

Compound 4, half-maximal inhibitory concentration: > 20000 nM
Compound 4 ended at the assay's limit; the forecaster's own chance of this, stated with the estimate: 20%; the middle value lies on the limit itself.
By their numbers in this assay, from the lowest: compound 1; then compounds 2 and 3 (each within the scatter of the next). At a limit, above all of these: compound 4.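

In this assay compound 4 gives > 20000 nM, which is a limit of the assay and not a number: the limit of > 20000 nM in this assay, at which 1 of the 4 values shown sits.

On this aromatic carbon, meta to a large group, carbamoyl is the first of the three groups shown to bring a hydrogen-bond donor, and it did not bring the number down, with an at least 1.2-fold higher number from compound 3 to compound 4 (0.08 log units; that floor lies within the scatter) and an at least 1.5-fold higher number from compound 2 to compound 4 (0.19 log units; that floor lies within the scatter). Both steps are floors, so the result rules out a gain from this change but does not show that carbamoyl differs beyond the scatter from methoxy or methylsulfanyl.

On these data alone, how far compound 4 lies past the limit stays open. So does whether an amine or a carboxylic acid on this same carbon would give a lower number in this assay.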